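From hex-1-yn-1-yl to benzyl on the shared core

The compounds below may be only part of what the source reports. "The series", "measured", "known", "first", "only" and "open" are said of these compounds alone.

In an ADME assay on J774 cells (Mus musculus) for cytotoxicity (on this read-out higher numbers stand for an effect only at larger amounts of compound and lower numbers for an effect already at smaller amounts), compound 1 `COc1ccc2[nH]c(C)c(Br)c(=O)c2c1` gives > 37300 nM as a limit of the assay. Compound 2 `CCCCC#Cc1c(C)[nH]c2ccc(OC)cc2c1=O` gives > 36800 nM and this, too, is only a limit. Compound 3 `COc1ccc2[nH]c(C)c(Cc3ccccc3)c(=O)c2c1`, not yet measured, carries benzyl in place of hex-1-yn-1-yl on an aromatic carbon of the shared core. For the measured compounds named here, the only measured step, a step that the two limits leave unreadable from compound 1 to compound 2, offers no size to carry over. In this assay the expected step of an at least 1.0-fold lower number from compound 2 to compound 3 (0.00 log units; that floor lies within the scatter) is therefore none beyond the scatter, and a further limit is likely. For compound 3 the estimate is 36000 nM with an expected range from 15000 nM to 50000 nM as its ends.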

Compound 3, half-maximal effective concentration: > 23700 nM
Compound 3 was reported as a limit; the forecaster's own chance of this, stated with the estimate: 80%; the middle value is on the limit's open side.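

In this assay compound 3 gives > 23700 nM, which is a limit. For the compounds shown here, compound 1 and compound 2 are also limits, so no step to compound 3 can be read. The compounds shown leave open at what concentration any of them reaches its half-maximal effect.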